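Removing the Methoxy Group: What Compound 3 May Show

This account rests on a few compounds, and the source may have more. Where it says the series, first, only, none or still open, it means among the compounds named here.

Measured so far:
compound 1, `CCn1c(SCC(=O)Nc2ccc(C(C)=O)cc2)nnc1-c1ccc(OC)cc1`: 65%
compound 2, `COc1ccc(-c2nnc(SCC(=O)Nc3ccc(C(C)=O)cc3)n2-c2ccccc2)cc1`: 63%

In a functional assay on the whole organism (strain albino) for inhibition, with Rattus norvegicus as the target, read by paw edema, with stated times of 30 min and 4 h, at a dose of 0.28 mmol/kg by the oral route (a higher number here means more inhibition at the dose given (going by the name of the read-out), a lower number less inhibition), compound 1 gives 65%. Compound 2 gives 63% in this assay. Going by the values given here, the only step between the two measured compounds is a number 2 percentage points lower from compound 1 to compound 2 (within the scatter), so the pair shows no difference beyond the scatter. Compound 2 has the lower of the two numbers on paper, but the gap to compound 1 is within the scatter, and the two numbers are level.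

Compound 3, `CC(=O)c1ccc(NC(=O)CSc2nnc(-c3ccccc3)n2-c2ccccc2)cc1`, is reached from compound 2 by the change (hydrogen in place of methoxy on an aromatic carbon). Among the compounds with values here, no measured step bears on this change: the one step recorded concerns a substituent on an aromatic nitrogen, not a methoxy on a carbon ring, and it was within the scatter. With nothing to suggest a large move either way, the step of a number 3 percentage points lower from compound 2 to compound 3 (within the scatter) is expected to stay within the scatter. Compound 3 is therefore estimated at 60%, with a range from 45% to 75%.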

Compound 3, a percentage reported as inhibition, in the whole organism at one dose (the size of the read-out at that dose, not a potency): 67%
Compound 3: middle estimate off by 7 percentage points, on the low side, and the stated range covers the measured number.
By their numbers in this assay, from the lowest: compounds 2, 1 and 3 (each within the scatter of the next).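

In this assay, hydrogen in place of methoxy on an aromatic carbon, para to a large group, gives a number 4 percentage points higher from compound 2 to compound 3 (within the scatter), so this step shows no difference beyond the scatter. Going by these compounds alone, the earlier pair spoke only to the substituent on the aromatic nitrogen; this step is the first reading at the carbon ring, and it shows that, with phenyl on the nitrogen, the 4-methoxyphenyl group can give way to plain phenyl with the inhibition at this dose staying level. No measurement is at hand that could explain this result or say what the methoxy group does or does not contribute.

The compounds shown leave open whether the same exchange would also read level with ethyl on the nitrogen, since only the phenyl-bearing pair covers it. They also test this ring place with only methoxy and hydrogen, so an amine or a carboxylic acid there could still move the number beyond the scatter, and a single dose says nothing of potency.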